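The source may report more compounds than this note shows. Statements on the series, on what has been measured and on what is new or still open speak of the compounds shown alone.

Compound 3 `O=S1(=O)CCC(CNCCCCN(C[C@H]2Cc3ccccc3CN2)[C@H]2CCCc3cccnc32)CC1` belongs to a small set of amines that share one core and differ only in the group on a saturated chain carbon bound to an amine nitrogen. In a functional assay on cells for agonist activity at C-X-C chemokine receptor type 4 (Homo sapiens), read by fluorescence and calcium flux, with a stated time of 90 s (a lower number here means that less compound is needed, a higher number that more compound is needed for the effect), compound 3 gives > 30000 nM, which is a limit of the assay and not a number. Compound 1 `c1cncc(CNCCCCN(C[C@H]2Cc3ccccc3CN2)[C@H]2CCCc3cccnc32)c1` carries a pyridin-3-yl at that position; in this assay compound 1 gives > 30000 nM, again a limit. Compound 2 `c1ccc2c(c1)CN[C@@H](CN(CCCCNCC1CCCCC1)[C@H]1CCCc3cccnc31)C2` carries a cyclohexyl there; in this assay compound 2 gives > 30000 nM, also a limit. The steps a step that the two limits leave unreadable from compound 1 to compound 2, a step that the two limits leave unreadable from compound 1 to compound 3 and a step that the two limits leave unreadable from compound 2 to compound 3 therefore cannot be read, since (the limit of > 30000 nM in this assay, at which 3 of the 3 values shown sit). Compound 3 thus stands at the limit together with the other two, with nothing in the numbers to set them apart.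

Compound 4 `O=S1(=O)CCC(NCCCCN(C[C@H]2Cc3ccccc3CN2)[C@H]2CCCc3cccnc32)CC1` differs from compound 3 by 1,1-dioxothian-4-yl in place of (1,1-dioxothian-4-yl)methyl on an amine nitrogen. For the measured compounds named here, none of the measured steps concerns a change of this kind, and the three that exist are unreadable, so they point to no direction and rule none out. The expectation for compound 4 is that it remains at the limit as well, which corresponds to an estimated step of a number no higher from compound 3 to compound 4 (the limit leaves the size open). Compound 4 is therefore expected at 30000 nM, within 8000 nM to 100000 nM.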

Compound 4, half-maximal effective concentration: > 30000 nM
Compound 4 was reported as a limit (the forecaster's own chance of this, stated with the estimate: 85%); the middle value sits exactly at the limit.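

In this assay compound 4 gives > 30000 nM, a limit of the assay and not a number. The steps from compound 1, compound 2 and compound 3 to compound 4 therefore cannot be read: the limit of > 30000 nM in this assay, at which 4 of the 4 values shown sit. The compounds shown leave open whether any group at that place on the shared core gives a measurable value in this assay.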